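Aryl amide swap on the phenyl-bearing core: compound 2 to 4

The source may report more compounds than this note shows. Statements on the series, on what has been measured and on what is new or still open speak of the compounds shown alone.

Compound 2 `Cc1ccc(F)cc1NC(=O)CN1CCN(c2nnc(Cc3ccccc3)c3ccccc23)CC1` stands at the top of the three numbers in a functional assay on MDA-MB-231 cells (Homo sapiens) for cytotoxicity, read by MTT assay, with a stated time of 72 h (on this read-out higher numbers stand for weaker inhibition and lower numbers for stronger inhibition), where compound 2 gives 19200 nM. Going by the values given here, compound 1 `Cc1cccc(Cl)c1NC(=O)CN1CCN(c2nnc(Cc3ccncc3)c3ccccc23)CC1` gives 2670 nM in this assay, and compound 3 `O=C(CN1CCN(c2nnc(Cc3ccncc3)c3ccccc23)CC1)Nc1cccc(Br)c1` gives 1.7 nM, the lowest of the set; the step of a 1600-fold lower number from compound 1 to compound 3 (3.20 log units; beyond the scatter) is the only single-point comparison measured so far. Compound 1 and compound 2 differ in two places, so their values are shown without a step. Compound 4 `Cc1ccc(NC(=O)CN2CCN(c3nnc(Cc4ccccc4)c4ccccc34)CC2)c(C)c1` is the next member: 2,4-dimethylphenyl in place of 5-fluoro-2-methylphenyl on an amide-type nitrogen.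

The measured step from compound 1 to compound 3 bears on the same amide-type nitrogen and shows that exchanging the aryl group there can move the number very far, but that exchange also removed an ortho pattern, whereas compound 4 keeps a methyl in the 2-position. The direction for this assay is therefore uncertain; a modest lowering is expected, a 2.4-fold lower number from compound 2 to compound 4 (0.38 log units; beyond the scatter). Compound 4 is estimated at 8000 nM, within a range of 1500 nM to 40000 nM.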

Compound 4, half-maximal inhibitory concentration: 181000 nM
Compound 4: middle estimate off by 23-fold (1.35 log units), on the low side; the whole stated range lies below it.
By their numbers in this assay, from the lowest: compound 3; then compound 1; then compound 2; then compound 4.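

In this assay, exchanging 5-fluoro-2-methylphenyl for 2,4-dimethylphenyl on the amide-type nitrogen gives a 9.4-fold higher number from compound 2 to compound 4 (0.97 log units; beyond the scatter) even though the heavy-atom count, the ring type and the donor and acceptor counts of the group stay the same. Read with a 1600-fold lower number from compound 1 to compound 3 (3.20 log units; beyond the scatter) on the core of compound 1, this shows that an aryl exchange on this nitrogen can move the number in either direction, though the two steps are different exchanges on different cores. Nothing available here accounts for the size or direction of the new step.

No single aryl group appears on both cores among the compounds shown, so the part played by the core remains open. Also open, as far as these compounds go, is how this position responds to an aryl ring carrying an amine or a carboxylic acid.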